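A few compounds are considered here, and "the series" means these few. Any claim that something is new, unique, unknown or untested is made for them only; others in the source may bear on it.

Measured compounds:
- compound 1 `Cc1ccc(NC(=O)N[C@H](C)c2ccccc2)cc1`: 100%
- compound 2 `Cc1ccc(NC(=O)N[C@@H](C)c2ccccc2)cc1`: 100%
- compound 3 `CCOC(=O)c1cccc(NC(=O)N[C@@H](C)c2ccccc2)c1`: 100%

In an ADME assay on the whole organism with Oryza sativa as the target, tested at 0.1 uM (a lower number here means a stronger effect, a higher number a weaker effect of the compound at the concentration tested), compound 2 gives 100%, level with compound 1 and compound 3 at the digits shown. Within the data shown here, the only step among the measured compounds that differs in one place is no change at the digits printed from compound 1 to compound 2 (within the scatter); the two compounds share all atoms and bonds, and the only difference is the fact that compounds 1 and 2 differ only in the configuration as drawn. Among the measured compounds shown here, compound 3, which carries its ester on a different aromatic carbon of the shared core, also sits at the same value, so no measured step moves the read-out at all.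

The unmeasured compound 4 `CC(=O)c1ccc(NC(=O)N[C@@H](C)c2ccccc2)cc1` differs from compound 2 by acetyl in place of methyl on an aromatic carbon. For the measured compounds named here, no measured pair tests the exchange of methyl for acetyl, so the step from compound 1 to compound 2 and the flat values of compound 3 are the only guide: every change tried so far leaves the read-out where it was. The expected step in this assay is therefore no change at the digits printed from compound 2 to compound 4 (within the scatter), none beyond the scatter. Compound 4 is expected to give 100%, with a range from 88% to 100%.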

Compound 4, a percentage reported as activity, at one concentration (the size of the read-out at that concentration, not a potency): 99%
For compound 4 the middle estimate is 1 percentage points above the measured one; measured number inside the range.
By their numbers in this assay, from the lowest: compounds 4, 1, 2 and 3 (each within the scatter of the next).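

In this assay, the exchange of methyl for acetyl on an aromatic carbon, para to a large group, gives a number 1 percentage points lower from compound 2 to compound 4 (within the scatter), so this position takes a group of 3 heavy atoms, with a double bond outside the aromatic rings and a hydrogen-bond acceptor, in place of a single carbon without a step beyond the scatter. Among these compounds, until now, the only one-place step was a change of drawn configuration, so this is the first one-place step that alters the atoms of the compound, and at this position it leaves the read-out within the scatter. Nothing available bears on why the exchange of methyl for acetyl gives this result.

From the compounds shown here alone, whether an amine or a carboxylic acid at this position, or a longer chain in place of acetyl, would move the read-out beyond the scatter remains open. Since all the compounds shown lie within the scatter of each other at the single concentration tested, the series also leaves open which structural changes, if any, can produce a lower number in this assay.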